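The source may hold more compounds than are shown below. What is called first, only, known or untested is meant among the compounds shown, and "the series" means these compounds.

In an ADME assay on CEM-SS cells (Homo sapiens) for cytotoxicity, read by XTT assay, with a stated time of 6 days (a lower number here means that less compound is tolerated, a higher number that more compound is tolerated), compound 1 (`CCCC(=O)OCSc1ccccc1C(=O)NCCCCCCC(N)=O`) gives 10.4 uM. Compound 2 (`CCCC(=O)OCSc1ccccc1C(=O)NCC(=O)NC`) gives > 100 uM, which is a limit of the assay and not a number. Compound 3 (`CCCC(=O)OCSc1ccccc1C(=O)NCC(=O)N(C)C`) differs from compound 2 by methyl in place of hydrogen on an amide-type nitrogen. Among the compounds with values here, the one measured step, an at least 9.6-fold higher number from compound 1 to compound 2 (0.98 log units; beyond the scatter), lies beyond the scatter, but it exchanges 5-carbamoylpentyl for methylcarbamoyl and so gives only weak guidance on this change. The expected a number no higher from compound 2 to compound 3 (the limit leaves the size open) in this assay stays within the scatter. Compound 3 is estimated at 100 uM, with an expected range from 35 uM to 200 uM.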

Compound 3, half-maximal toxic concentration: 38.3 uM
Beside the measured number, compound 3's estimate is 2.6-fold (0.42 log units) above it, and the stated range covers the measured number.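

In this assay, methyl in place of hydrogen on an amide-type nitrogen gives an at least 2.6-fold lower number from compound 2 to compound 3 (0.41 log units; beyond the scatter) and so this nitrogen responds to the change. Dimethylcarbamoyl in place of 5-carbamoylpentyl still gives a 3.7-fold higher number from compound 1 to compound 3 (0.57 log units; beyond the scatter) and so part of the earlier rise remains. The first of these steps has no upper bound, because compound 2 stands at a limit of the assay and not at a number: the limit of > 100 uM in this assay, at which 1 of the 3 values shown sits.

As far as these compounds go, whether an ethyl group or a longer chain on this nitrogen moves the number further stays open. This single pair cannot separate the added methyl from the lost amide hydrogen.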